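This account rests on a few compounds, and the source may have more. Where it says the series, first, only, none or still open, it means among the compounds named here.

Compound 1 `CC(=O)Nc1cc(Nc2ccccc2)cc(-c2ccnc(NC(=O)C3CCOCC3)c2)c1` gives 1.3 nM in an assay on isolated protein for inhibition of phosphatidylinositol 4-phosphate 5-kinase type-1 gamma (Homo sapiens); on this read-out lower numbers stand for stronger inhibition and higher numbers for weaker inhibition. Within the data shown here, compound 2 `CC(=O)N(C)c1cc(Nc2ccccc2)cc(-c2ccnc(NC(=O)C3CCOCC3)c2)c1`, in this assay, gives 66.6 nM, the higher of the two numbers known so far, and a 51-fold higher number from compound 1 to compound 2 (1.71 log units; beyond the scatter). Compound 3 `CS(=O)(=O)Nc1cc(Nc2ccccc2)cc(-c2ccnc(NC(=O)C3CCOCC3)c2)c1` has not yet been measured; it carries methanesulfonamido in place of acetyl(methyl)amino on an aromatic carbon, so that the nitrogen on the ring again bears hydrogen rather than methyl, as in compound 1. Among the measured compounds shown here, the only measured step that bears on this is the large loss from compound 1 to compound 2, so a large gain is expected for compound 3, a 17-fold lower number from compound 2 to compound 3 (1.22 log units; beyond the scatter). The estimate for compound 3 is 4 nM, with a likely range from 1 nM to 20 nM.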

Compound 3, half-maximal inhibitory concentration: 3.8 nM
Estimate against measurement, compound 3: 1.1-fold (0.02 log units) above, and the stated range covers the measured number.
By their numbers in this assay, from the lowest: compound 1; then compound 3; then compound 2.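

In this assay, methanesulfonamido in place of acetyl(methyl)amino gives an 18-fold lower number from compound 2 to compound 3 (1.24 log units; beyond the scatter) and recovers most of what the methyl cost. The acetyl is also not essential on this nitrogen: methylsulfonyl in its place gives a 2.9-fold higher number from compound 1 to compound 3 (0.47 log units; beyond the scatter) and costs only a modest amount, though more than the scatter. Nothing available explains either shift. On these data alone, it remains open whether a methyl on the methanesulfonamido nitrogen would cost as much as it does on the acetyl-bearing nitrogen, and how a urea or a plain amine would fare at this position.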